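The compounds below may be only part of what the source reports. "The series", "measured", "known", "first", "only" and "open" are said of these compounds alone.

Measured so far:
Compound 1 `CCCCCCC(CCO)n1cnc2c(NC)ncnc21`: > 50000 nM
Compound 2 `CCCCCCCC(CCO)n1cnc2c(NC)ncnc21`: 15300 nM
Compound 3 `CCCCCCCC[C@H](CCO)n1cnc2c(Cl)ncnc21`: 320 nM

In a functional assay on SW480 cells (Homo sapiens) for antiproliferative activity, read by MTT assay, with a stated time of 48 h (a lower number here means a stronger inhibitor, a higher number a weaker inhibitor), compound 1 reaches only the limit (the limit of > 50000 nM in this assay, at which 1 of the 3 values shown sits), which is a limit of the measurement and not a number. Compound 2 gives 15300 nM in this assay, so the change methyl in place of hydrogen on a saturated chain carbon, seven bonds along the chain from an aromatic nitrogen brings an at least 3.2-fold lower number from compound 1 to compound 2 (0.51 log units; beyond the scatter). Compound 3 differs in its core from compound 1 in a way not broken down here; in this assay compound 3 gives 320 nM, the lowest number among the measured compounds. Compound 4 `CCCCCCCCC[C@H](CCO)n1cnc2c(Cl)ncnc21` has not yet been measured. It differs from compound 3 by methyl in place of hydrogen on a saturated chain carbon, nine bonds along the chain from an aromatic nitrogen, the same kind of change as between compound 1 and compound 2, but at a place nine rather than seven bonds along the chain from the aromatic nitrogen. Resting on the step of an at least 3.2-fold lower number from compound 1 to compound 2 (0.51 log units; beyond the scatter), a modest improvement is expected, a 2.0-fold lower number from compound 3 to compound 4 (0.30 log units; within the scatter). Compound 4 is therefore estimated at 160 nM, between 60 nM and 500 nM.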

Compound 4, half-maximal inhibitory concentration: 1630 nM
Compound 4: middle estimate off by 10-fold (1.01 log units), on the low side; measured number above the stated range.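

In this assay, the added methyl brings a 5.1-fold higher number from compound 3 to compound 4 (0.71 log units; beyond the scatter), which runs opposite to the earlier step on the other core. The same change therefore does not carry over unchanged from one core to the other in this series, and the two steps differ clearly: the same change on two cores in this assay, an at least 3.2-fold lower number (0.51 log units; beyond the scatter) from compound 1 to compound 2 and a 5.1-fold higher number (0.71 log units; beyond the scatter) from compound 3 to compound 4, at least 16-fold (1.22 log units) apart, beyond the scatter of two such steps

Going by these compounds alone, with only one pair on each core, this does not show why the steps differ, nor whether the core or the starting chain length sets the direction. The compounds shown leave open how a longer chain than that of compound 4 would fare on its core. They also leave open whether the chain on the other core would keep improving with further lengthening.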